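Second phenyl on the core of compound 1

The compounds below may be only part of what the source reports. "The series", "measured", "known", "first", "only" and "open" are said of these compounds alone.

Compound 1 `O=C(NCCCCCCn1cc(-c2ccccc2)c2ccccc21)Oc1ccccc1` gives 4900 nM in an assay on microsomes from brain (strain Sprague-Dawley) for inhibition of Fatty-acid amide hydrolase 1 (Rattus norvegicus), read by fluorescence and HPLC, with stated times of 10 min and 60 min (a higher number here means a weaker inhibitor, a lower number a stronger inhibitor), and stands highest of the three numbers in hand. Compound 3 `O=C(NCCCCCCn1ccc2ccccc21)Oc1ccccc1` gives 250 nM and compound 2 `O=C(NCCCCCn1ccc2ccccc21)Oc1cccnc1` gives 3.6 nM. Among the measured compounds shown here, the only single-point step recorded is a 20-fold lower number from compound 1 to compound 3 (1.29 log units; beyond the scatter): taking the phenyl off compound 1 leaves a far stronger inhibitor. Compound 4 `O=C(NCCCCCCn1c(-c2ccccc2)c(-c2ccccc2)c2ccccc21)Oc1ccccc1` goes the other way: phenyl in place of hydrogen on an aromatic carbon, the entering group sitting on the aromatic carbon next to the ring nitrogen and next to the ring atom that bears a phenyl group. For the measured compounds named here, no measured pair shows two phenyls on the shared core, so the step between compound 3 and compound 1 is the only guide; it was large and towards a weaker inhibitor, and a second phenyl on the same five-membered ring is expected to move the number further in that direction, probably by a smaller margin than the first. Compound 4 is therefore expected to give 15000 nM (range 3000 nM to 60000 nM), which is an expected 3.1-fold higher number from compound 1 to compound 4 (0.49 log units; beyond the scatter).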

Compound 4, half-maximal inhibitory concentration: 4700 nM
The estimate for compound 4 lay 3.2-fold (0.50 log units) above the measured number; low and high end bracket the measured number.
By their numbers in this assay, from the lowest: compound 2; then compound 3; then compounds 4 and 1 (each within the scatter of the next).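

In this assay, phenyl in place of hydrogen on the aromatic carbon next to the ring nitrogen gives a 1.0-fold lower number from compound 1 to compound 4 (0.02 log units; within the scatter), so on this core a second phenyl at this position shows no change in the number. The two phenyl positions therefore differ in this series: hydrogen in place of the phenyl already present on compound 1 gives a 20-fold lower number from compound 1 to compound 3 (1.29 log units; beyond the scatter), a large step, whereas the entering phenyl gives a step within the scatter. Nothing measured on these compounds accounts for that difference.

As far as these compounds go, whether the flat result depends on the phenyl already present remains open, as a phenyl at this carbon on the core of compound 3 would test that. Also open, from the compounds shown here alone, is how a smaller or different group on the same carbon, such as methyl, an amine or a carboxylic acid, would read.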